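Urea aryl exchange: from compound 2 to compound 3

A few compounds are considered here, and "the series" means these few. Any claim that something is new, unique, unknown or untested is made for them only; others in the source may bear on it.

Values so far in a functional assay on L1210 cells (Mus musculus) for inhibition, read by MTT assay, with a stated time of 72 h; a lower number here means a stronger inhibitor, a higher number a weaker inhibitor:
- compound 1 `COc1cc(NC(C)CCCNC(=O)Nc2ccc(Br)cc2)c2ncccc2c1` gives 18000 nM
- compound 2 `COc1cc(NC(C)CCCNC(=O)Nc2cccc(C(F)(F)F)c2)c2ncccc2c1` gives 9200 nM

Among the compounds with values here, compound 2 cannot be separated from compound 1 on these numbers, the only other measured compound. Within the data shown here, the one measured step, a 2.0-fold lower number from compound 1 to compound 2 (0.29 log units; within the scatter), stays within the scatter.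

On these data alone, compound 3 `COc1cc(NC(C)CCCNC(=O)Nc2ccc(Cl)cc2)c2ncccc2c1` is untested. It carries 4-chlorophenyl in place of 3-(trifluoromethyl)phenyl on an amide-type nitrogen, with the rest of compound 2 unchanged. The measured step bears on this directly, as it concerns the same place. Among the measured compounds shown here, with only that small exchange to go on, no step beyond the scatter is expected, and no direction can be claimed.

The expected step is a 1.4-fold higher number from compound 2 to compound 3 (0.15 log units; within the scatter) in this assay on this reading. The estimated value for compound 3 is 13000 nM (expected range 6500 nM to 25000 nM).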

Compound 3, half-maximal inhibitory concentration: 19000 nM
Compound 3: the middle estimate sits 1.5-fold (0.16 log units) below what was measured; low and high end bracket the measured number.
By their numbers in this assay, from the lowest: compounds 2, 1 and 3 (each within the scatter of the next, the first and the last beyond it).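

In this assay, within the data shown here, 4-chlorophenyl in place of 3-(trifluoromethyl)phenyl on an amide-type nitrogen gives a 2.1-fold higher number from compound 2 to compound 3 (0.31 log units; beyond the scatter), the first step at this position to pass the scatter, and only modestly. Chloro in place of bromo on an aromatic carbon gives a 1.1-fold higher number from compound 1 to compound 3 (0.02 log units; within the scatter), so 4-chlorophenyl and 4-bromophenyl cannot be told apart here, and the aryl exchanges so far move the number very little. No evidence available here explains either step.

Still open, on these data alone, is whether a larger change on this nitrogen, such as an aryl group carrying an amine or a carboxylic acid, would move the number well beyond the scatter. The compounds shown also say nothing about a longer chain between the shared core and the urea.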